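Swapping a hydroxyphenyl for a fluorophenyl on the chain

The compounds below may be only part of what the source reports. "The series", "measured", "known", "first", "only" and "open" are said of these compounds alone.

Compound 1 `Cc1ccc(S(=O)(=O)NC(=O)Nc2ccccc2C(=O)/C=C/c2cccc(O)c2)cc1` is measured in an ADME assay on the whole organism for cytotoxicity, with Artemia salina as the target, with a stated time of 24 h (on this read-out lower numbers stand for an effect already at smaller amounts and higher numbers for an effect only at larger amounts of compound), where compound 1 gives 39.3 ug/mL, the highest of the three numbers shown, though its gap to compound 2 `Cc1ccc(S(=O)(=O)NC(=O)Nc2ccccc2C(=O)/C=C/c2ccc(O)cc2)cc1` lies within the scatter; compound 2 gives 24.3 ug/mL and compound 3 `COc1cc(/C=C/C(=O)c2ccccc2NC(=O)NS(=O)(=O)c2ccc(C)cc2)ccc1O` gives 17.8 ug/mL. Compound 4 `Cc1ccc(S(=O)(=O)NC(=O)Nc2ccccc2C(=O)/C=C/c2ccc(F)cc2)cc1` differs from compound 1 by 4-fluorophenyl in place of 3-hydroxyphenyl on a double-bonded chain carbon bound to a double-bonded chain carbon. The known steps change only the hydroxy-bearing ring: a 1.6-fold lower number from compound 1 to compound 2 (0.21 log units; within the scatter) and a 2.2-fold lower number from compound 1 to compound 3 (0.34 log units; beyond the scatter). Neither removes the hydroxy nor adds fluorine, so they bear only loosely on this change, and at most a modest shift is expected. Compound 4 is therefore estimated at 26 ug/mL, with a range from 12 ug/mL to 55 ug/mL, which means an expected 1.5-fold lower number from compound 1 to compound 4 (0.18 log units; within the scatter).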

Compound 4, concentration for half-maximal effect: 3.96 ug/mL
Beside the measured number, compound 4's estimate is 6.6-fold (0.82 log units) above it; measured number outside the range, below it.
By their numbers in this assay, from the lowest: compound 4; then compounds 3, 2 and 1 (each within the scatter of the next, the first and the last beyond it).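

In this assay, the plainest view of this change is fluoro in place of hydroxy on an aromatic carbon, with a 6.1-fold lower number from compound 2 to compound 4 (0.79 log units; beyond the scatter). The wider ring swaps give a 9.9-fold lower number from compound 1 to compound 4 (1.00 log units; beyond the scatter) and a 4.5-fold lower number from compound 3 to compound 4 (0.65 log units; beyond the scatter), so replacing the hydroxy-bearing ring moves the number further than any step among the hydroxy-bearing rings did. No measurement shown gives a reason for this drop.

Still open, from the compounds shown here alone, is whether the incoming fluoro or the departing hydroxy accounts for the step, which a plain phenyl or a 4-chlorophenyl on the same chain carbon could help separate. Going by these compounds, whether a 3-fluorophenyl would behave like the 4-fluorophenyl is also open.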